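The source may hold more compounds than are shown below. What is called first, only, known or untested is meant among the compounds shown, and "the series" means these compounds.

The measured compounds:
compound 1, `O=C(NCCCCO)c1cc(-c2ccc(Cl)cc2Cl)n[nH]1`, gives 35 nM in an assay on isolated protein for inhibition of alkaline phosphatase, tissue-nonspecific isozyme (Homo sapiens); a lower number here means a stronger inhibitor, a higher number a weaker inhibitor.
compound 2, `CCN(CC)C(=O)c1cc(-c2ccc(Cl)cc2Cl)n[nH]1`, gives 285 nM in this assay.

For the measured compounds named here, compound 2 stands highest of the two numbers; its nearest neighbour is compound 1, and the one step between them, an 8.1-fold higher number from compound 1 to compound 2 (0.91 log units; beyond the scatter), lies beyond the scatter. The pair shares the same core and differs only at the carbonyl carbon, where a group with two hydrogen-bond donors in compound 1 gave the lower number than the diethylamino group of compound 2.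

Compound 3, `NNC(=O)c1cc(-c2ccc(Cl)cc2Cl)n[nH]1`, is not yet measured. It differs from compound 2 by aminoamino in place of diethylamino on a carbonyl carbon. Going by the values given here, the only step that bears on this change is the one from compound 1 to compound 2, in which a group carrying donors was exchanged for one without; compound 3 restores donors at that carbonyl carbon, though with a shorter group than compound 1. A step back down in this assay is therefore expected, of the order a 4.1-fold lower number from compound 2 to compound 3 (0.61 log units; beyond the scatter), and compound 3 is estimated at 70 nM, within a range of 20 nM to 250 nM.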

Compound 3, half-maximal inhibitory concentration: 44 nM
The estimate for compound 3 lay 1.6-fold (0.20 log units) above the measured number, within the range that was stated.
By their numbers in this assay, from the lowest: compounds 1 and 3 (each within the scatter of the next); then compound 2.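

In this assay, the change at the carbonyl carbon runs the other way from the earlier step: aminoamino in place of diethylamino gives a 6.5-fold lower number from compound 2 to compound 3 (0.81 log units; beyond the scatter), so the number falls again when diethylamino leaves. The more telling comparison is a 1.3-fold higher number from compound 1 to compound 3 (0.10 log units; within the scatter). It shows that amino and 4-hydroxybutyl on the amide-type nitrogen cannot be told apart here, even though 4-hydroxybutyl is a whole chain and amino is not; the chain of compound 1 is thus not needed for a number of this size, and among these three compounds the only one standing apart is compound 2, the one with no hydrogen-bond donors in this group, with none going against that reading. No measurement shown here explains why the number moves at this position.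

The compounds shown leave open whether the hydrogen-bond donors or the size of diethylamino set the number apart, since both differ in the same step. A dimethylamino group, a plain butylamino chain without its hydroxyl, or a methylamino group on the same carbonyl carbon would bear on that question.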